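Replacing Trifluoromethyl in a Compound Held at an Assay Limit

The compounds below may be only part of what the source reports. "The series", "measured", "known", "first", "only" and "open" are said of these compounds alone.

Compound 1 `O=C1NC(c2ccccc2)CN1S(=O)(=O)c1ccc2c(c1)CCCN2C(=O)C(F)(F)F`: 19600 nM
Compound 2 `O=C(CCl)NC(=O)N1CCCc2cc(S(=O)(=O)N3CC(c4ccccc4)NC3=O)ccc21`: 6140 nM
Compound 3 `CC1(c2ccccc2)CN(S(=O)(=O)c2ccc3c(c2)CCCN3C(=O)C(F)(F)F)C(=O)N1`: > 20000 nM (a limit)

In a functional assay on SK-OV-3 cells (Homo sapiens) for antiproliferative activity, read by MTT assay (on this read-out lower numbers stand for stronger inhibition and higher numbers for weaker inhibition), compound 3 is known only through a limit of > 20000 nM and has no exact number. Compound 4 `COc1ccc(NC(=O)N2CCCc3cc(S(=O)(=O)N4CC(C)(c5ccccc5)NC4=O)ccc32)cc1` differs from compound 3 in one place: (4-methoxyphenyl)amino in place of trifluoromethyl on a carbonyl carbon. In words, (4-methoxyphenyl)amino stands in place of trifluoromethyl on a carbonyl carbon.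

Within the data shown here, two measured steps bear on this change. The closer one is a 3.2-fold lower number from compound 1 to compound 2 (0.50 log units; beyond the scatter), a modest step beyond the scatter that also replaces trifluoromethyl on a carbonyl carbon, though with a different entering group. The other is an at least 1.0-fold higher number from compound 1 to compound 3 (0.00 log units; that floor lies within the scatter), whose floor lies within the scatter. A modest step toward lower numbers is therefore expected in this assay, although the limit leaves its starting point open.

The estimated change is an at least 2.8-fold lower number from compound 3 to compound 4 (0.45 log units; beyond the scatter). Compound 4 is estimated at 7000 nM, with an expected range from 2000 nM to 20000 nM.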

Compound 4, half-maximal inhibitory concentration: 9470 nM
For compound 4 the middle estimate is 1.4-fold (0.13 log units) below the measured one; low and high end bracket the measured number.
By their numbers in this assay, from the lowest: compounds 2 and 4 (each within the scatter of the next); then compound 1. At a limit, above all of these: compound 3.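

Placing (4-methoxyphenyl)amino on a carbonyl carbon in place of trifluoromethyl gives, in this assay, an at least 2.1-fold lower number from compound 3 to compound 4 (0.32 log units; beyond the scatter). This shows that a second, quite different entering group at this carbonyl carbon also lowers the number, now on the methyl-bearing core of compound 3 and not only on the core of compound 1, where the earlier change gave a 3.2-fold lower number from compound 1 to compound 2 (0.50 log units; beyond the scatter). The true size of the new step stays unknown, as compound 3 is held at a limit and the step is only a floor: the limit of > 20000 nM in this assay, at which 1 of the 4 values shown sits.

The compounds shown do not tell whether a simple amine such as dimethylamino on the same carbonyl carbon would also lower the number. Nor do they tell how much of the step belongs to the aromatic ring of the entering group and how much to its methoxy group.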